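Benzyl substitution on two amidine cores: expected step

The source may hold more compounds than are shown below. What is called first, only, known or untested is meant among the compounds shown, and "the series" means these compounds.

Compound 1 `Cn1nc(-c2ccccc2)c2cc(C(=N)Nc3ccccc3)ncc21` and compound 2 `COc1ccc(Cn2nc(-c3ccccc3)c3cc(C(=N)Nc4ccccc4)ncc32)cc1` share one core; compound 3 `Cn1cc2cc(C(=N)Nc3ccccc3)ncc2n1` and compound 4 `COc1ccc(Cn2cc3cc(C(=N)Nc4ccccc4)ncc3n2)cc1` share another, and the difference between the two cores is not broken down here. In a functional assay on HT-1080 cells (Homo sapiens) for cytotoxicity, read by MTT assay, with a stated time of 72 h (on this read-out higher numbers stand for weaker inhibition and lower numbers for stronger inhibition), compound 1 gives 17400 nM and compound 2 gives 4700 nM; the change 4-methoxyphenyl in place of hydrogen on a saturated chain carbon bound to an aromatic nitrogen gave a 3.7-fold lower number from compound 1 to compound 2 (0.57 log units; beyond the scatter). For compound 3 the entry in this assay reads "not determined" (no result reported), so no number is available for it. Going by the values given here, the change 4-methoxyphenyl in place of hydrogen on a saturated chain carbon bound to an aromatic nitrogen is the same change made on the second core, and the same size of step is expected from compound 3 to compound 4 in this assay, resting only on the one measured instance in compound 1 and compound 2. As the core of compound 3 lacks a part carried by compound 1, compound 4 is expected to sit near 15000 nM, between 3000 nM and 70000 nM.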

Compound 4, half-maximal inhibitory concentration: 1130 nM
Compound 4: middle estimate off by 13-fold (1.12 log units), on the high side; the measured number lies below the stated range.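

In this assay, going by these compounds alone, compound 3 has no number, so no step from it to compound 4 can be read. On these data alone, whether the 4-methoxyphenyl change gives a step of like size on both cores stays open, and no supporting data bear on this result.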